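The source may hold more compounds than are shown below. What is called first, only, known or untested is meant among the compounds shown, and "the series" means these compounds.

Of the compounds shown here, three that share one core have been tested in a functional assay; on this read-out higher numbers stand for weaker inhibition and lower numbers for stronger inhibition. Compound 1 `CC(C)=CCOc1cc(O)c2c(c1)OC(c1ccccc1Cl)CC2=O` gives 4270 nM, compound 2 `CC(C)=CCOc1cc(O)c2c(c1)OC(c1ccc(Cl)cc1Cl)CC2=O` gives 3340 nM, and compound 3 `CC(C)=CCOc1cc(O)c2c(c1)OC(c1ccc(Br)cc1)CC2=O` gives 2770 nM. Compound 3 therefore stands level with the other two, as all three numbers lie within the scatter of each other.

The next compound, compound 4 `CC(C)=CCOc1cc(O)c2c(c1)OC(c1ccc(C)cc1C)CC2=O`, keeps the core and has 2,4-dimethylphenyl in place of 4-bromophenyl on a saturated ring carbon.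

The measured steps that bear on this change all alter the aromatic group at that same place: a 1.3-fold lower number from compound 1 to compound 2 (0.11 log units; within the scatter), a 1.5-fold lower number from compound 1 to compound 3 (0.19 log units; within the scatter) and a 1.2-fold lower number from compound 2 to compound 3 (0.08 log units; within the scatter). Each of them is small and within the scatter. For the measured compounds named here, no compound with methyl groups on this aromatic ring has been measured yet, so the evidence is indirect, and no clear step in either direction is expected in this assay. The expected change is a 1.3-fold higher number from compound 3 to compound 4 (0.10 log units; within the scatter), which would not go beyond the scatter.

The estimate for compound 4 is 3500 nM, with an expected range from 1800 nM to 7000 nM.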

Compound 4, half-maximal inhibitory concentration: 6380 nM
For compound 4 the middle estimate is 1.8-fold (0.26 log units) below the measured one, within the range that was stated.
By their numbers in this assay, from the lowest: compounds 3, 2, 1 and 4 (each within the scatter of the next, the first and the last beyond it).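

In this assay, for the compounds shown here, the swap to 2,4-dimethylphenyl from 4-bromophenyl on the saturated ring carbon gives a 2.3-fold higher number from compound 3 to compound 4 (0.36 log units; beyond the scatter) and is the first step at this position to go beyond the scatter, though it is only modest. The steps of a 1.9-fold higher number from compound 2 to compound 4 (0.28 log units; within the scatter) and a 1.5-fold higher number from compound 1 to compound 4 (0.17 log units; within the scatter) both stay within the scatter, so compound 4 cannot be told apart from compound 2 or compound 1, and the four aromatic groups span only a narrow range of numbers. No measurement shown here offers an explanation for the step from 4-bromophenyl.

Still open, from the compounds shown here alone, is whether a phenyl ring carrying a single methyl group would give a similar number to compound 4. Also open, going by these compounds, is whether a phenyl ring carrying an amine or a carboxylic acid would shift the number much further in either direction.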